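Chloro for hydrogen on the pendant phenyl of compound 3

The source may hold more compounds than are shown below. What is called first, only, known or untested is meant among the compounds shown, and "the series" means these compounds.

Measured compounds:
compound 1 `COc1ccc(OC)c(-c2cc(-c3ccc(Cl)cc3)nn2-c2ccc(S(=O)(=O)NC(C)=O)cc2)c1` gives 67100 nM in a functional assay on cells (Cancer cell lines, Homo sapiens) for cytotoxicity, read by sulforhodamine B assay, with a stated time of 48 h; a higher number here means a weaker inhibitor of growth, a lower number a stronger inhibitor of growth
compound 2 `NS(=O)(=O)c1ccc(-n2nc(-c3ccc(Cl)cc3)cc2-c2cc(O)ccc2O)cc1` gives 50900 nM
compound 3 `CC(=O)NS(=O)(=O)c1ccc(-n2nc(-c3ccccc3)cc2-c2cc(O)ccc2O)cc1` gives 100000 nM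

Compound 3 stands at the highest of the three numbers in this assay, but the gaps to compound 1 and to compound 2 both lie within the scatter, so the three compounds cannot be put in order on these data. Compound 4 `CC(=O)NS(=O)(=O)c1ccc(-n2nc(-c3ccc(Cl)cc3)cc2-c2cc(O)ccc2O)cc1` has not been measured. It differs from compound 3 by chloro in place of hydrogen on an aromatic carbon. Within the data shown here, no pair of measured compounds differs in this place alone: compound 2 carries the chloro together with a primary sulfonamide, and compound 1 carries it with the acetylated sulfonamide but with methoxy groups in place of the hydroxyl groups. Both chloro-bearing compounds lie within the scatter of compound 3. The step from compound 3 to compound 4 is therefore expected to be a 1.7-fold lower number from compound 3 to compound 4 (0.22 log units; within the scatter), a small move toward a lower number that may not clear the scatter. Compound 4 is estimated at 60000 nM, with a range from 25000 nM to 130000 nM.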

Compound 4, concentration for total growth inhibition: 81200 nM
Beside the measured number, compound 4's estimate is 1.4-fold (0.13 log units) below it; the measured number falls inside the stated range.
By their numbers in this assay, from the lowest: compounds 2, 1, 4 and 3 (each within the scatter of the next).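

In this assay, phenyl to 4-chlorophenyl, now read with nothing else changing, gives a 1.2-fold lower number from compound 3 to compound 4 (0.09 log units; within the scatter), so chloro in place of hydrogen at this place leaves the number unresolved from that of the unsubstituted phenyl. With the chloro held fixed, acetyl in place of hydrogen on the sulfonamide nitrogen gives a 1.6-fold higher number from compound 2 to compound 4 (0.20 log units; within the scatter), and 2,5-dihydroxyphenyl in place of 2,5-dimethoxyphenyl gives a 1.2-fold higher number from compound 1 to compound 4 (0.08 log units; within the scatter), so none of the three single changes shown clears the scatter. No measured evidence is available to account for these steps.

On these data alone, whether an amine or a carboxylic acid at this place on the pendant ring would move the number beyond the scatter remains open. Also open, as far as these compounds go, is whether the chloro step would read the same with the primary sulfonamide or with the 2,5-dimethoxyphenyl group.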